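Methyl on the distal phenyl: compound 3 to compound 4

The source may report more compounds than this note shows. Statements on the series, on what has been measured and on what is new or still open speak of the compounds shown alone.

Three compounds of the series have been run in an ADME assay on NIH3T3 cells (Mus musculus) for cytotoxicity, read by MTT assay, with a stated time of 24 h; a higher number here means a weaker inhibitor, a lower number a stronger inhibitor. Compound 1 `O=C(CSc1ncccn1)N/N=c1/scc(-c2ccc([N+](=O)[O-])cc2)n1-c1ccccc1` gives 193 ug/mL, compound 2 `Cc1ccc(-c2cs/c(=N/NC(=O)CSc3nnnn3C)n2-c2ccccc2)cc1` gives 243 ug/mL, and compound 3 `O=C(CSc1ncccn1)N/N=c1/scc(-c2ccccc2)n1-c1ccccc1` gives 107 ug/mL. The number for compound 3 is the lowest of the three, but the step of a 1.8-fold lower number from compound 1 to compound 3 (0.26 log units; within the scatter) is within the scatter, so those two cannot be separated; only the gap from compound 3 to compound 2 is wider than the scatter.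

Compound 4 `Cc1ccc(-c2cs/c(=N/NC(=O)CSc3ncccn3)n2-c2ccccc2)cc1` differs from compound 3 in one place: methyl in place of hydrogen on an aromatic carbon. Going by the values given here, no measured step changes that ring by a methyl group alone. Among the compounds with values here, the one step on the same ring, a 1.8-fold lower number from compound 1 to compound 3 (0.26 log units; within the scatter), exchanged a nitro group for hydrogen and stayed within the scatter. Within the data shown here, compound 2 carries the methyl on this ring but also a different ring elsewhere in the molecule, so its value of 243 ug/mL shows only that a methyl-bearing analogue sits in the same range as the others.

On that basis the step of a 1.3-fold higher number from compound 3 to compound 4 (0.12 log units; within the scatter) in this assay is expected to stay within the scatter, with no clear direction. Compound 4 is estimated at 140 ug/mL, with a range from 70 ug/mL to 270 ug/mL.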

Compound 4, half-maximal inhibitory concentration: > 500 ug/mL
Compound 4: a limit, no number; the forecaster's own chance of this, stated with the estimate: 3%; middle value at least 3.5-fold (0.55 log units) away from the limit.
By their numbers in this assay, from the lowest: compounds 3, 1 and 2 (each within the scatter of the next, the first and the last beyond it). At a limit, above all of these: compound 4.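

In this assay the reading for compound 4 is a limit and not a number, so the steps that depend on it give only a lower bound on their size: the limit of > 500 ug/mL in this assay, at which 1 of the 4 values shown sits. The change from phenyl to 4-methylphenyl gives an at least 4.6-fold higher number from compound 3 to compound 4 (0.66 log units; beyond the scatter), so this position, para to a large group, can produce a step beyond the scatter, which the earlier change on this ring, a 1.8-fold lower number from compound 1 to compound 3 (0.26 log units; within the scatter), did not. Going by these compounds alone, with methyl in place of nitro the step is an at least 2.5-fold higher number from compound 1 to compound 4 (0.41 log units; beyond the scatter), and with the 4-methylphenyl held fixed, pyrimidin-2-yl in place of 1-methyl-1H-tetrazol-5-yl on the sulfur gives an at least 2.0-fold higher number from compound 2 to compound 4 (0.31 log units; beyond the scatter), so the group on the sulfur also registers, which no earlier pair could show.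

Going by these compounds, the true size of all three steps remains open, since each rests on the limit. Also open, on these data alone, are whether a longer chain such as ethyl, an amine or a carboxylic acid at the same ring position would move the number in the same direction, and whether the methyl step carries over when 1-methyl-1H-tetrazol-5-yl sits on the sulfur.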